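Removing a Fluoro Group Across Two Related Cores

The source may report more compounds than this note shows. Statements on the series, on what has been measured and on what is new or still open speak of the compounds shown alone.

Compound 1, `O=C1NC(c2ccccc2)(c2ccccc2)C(=O)N1CN1CCN(c2ccccc2)CC1`, gives 100 mg/kg in a functional assay on the whole organism (strain CD1) with Mus musculus as the target, in the maximal electroshock model, with a stated time of 4 h; on this read-out higher numbers stand for an effect only at larger amounts of compound and lower numbers for an effect already at smaller amounts.
Compound 2, `O=C1NC(c2ccccc2)(c2ccccc2)C(=O)N1CN1CCN(c2ccc(F)cc2)CC1`, gives 100 mg/kg in this assay.
Compound 3, `CC(C)C1(C(C)C)NC(=O)N(CN2CCN(c3ccccc3F)CC2)C1=O`, gives 100 mg/kg in this assay.

Compounds 1 and 2 share one core and differ by hydrogen in place of fluoro on an aromatic carbon. This change gave no change at the digits printed from compound 2 to compound 1 (within the scatter). Compound 3 carries another core; the difference between the two cores is not broken down here. Compound 4, `CC(C)C1(C(C)C)NC(=O)N(CN2CCN(c3ccccc3)CC2)C1=O`, differs from compound 3 by hydrogen in place of fluoro on an aromatic carbon. For the measured compounds named here, this is the same kind of change as the one between compounds 2 and 1, though the fluoro that leaves compound 3 sits ortho to a large group, whereas in compound 2 it sat para to a large group. Because that earlier change gave no change at the digits printed from compound 2 to compound 1 (within the scatter), a step of similar size is expected here, no change at the digits printed from compound 3 to compound 4 (within the scatter). Compound 4 is therefore estimated at 100 mg/kg, with a likely range from 50 mg/kg to 200 mg/kg.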

Compound 4, minimum effective dose: 300 mg/kg
Compound 4: middle estimate off by 3.0-fold (0.48 log units), on the low side, and the stated range ends below it.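

In this assay, the 2-fluorophenyl to phenyl change gave a 3.0-fold higher number from compound 3 to compound 4 (0.48 log units; beyond the scatter) and so did not repeat the result seen on the core of compound 1. Set side by side, the two steps differ: the same change on two cores in this assay, no change at the digits printed (within the scatter) from compound 2 to compound 1 and a 3.0-fold higher number (0.48 log units; beyond the scatter) from compound 3 to compound 4, 3.0-fold (0.48 log units) apart, beyond the scatter of two such steps. This shows that, among these compounds, the outcome of removing fluoro on one core does not carry over to the other, but it does not show why, as the two steps also differ in where the fluoro sits, and core and position cannot be separated here.

From the compounds shown here alone, whether a chloro or a methoxy group in place of the fluoro would behave alike on both cores remains open. So does the outcome of the change with the fluoro in the same place on both cores.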